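This account rests on a few compounds, and the source may have more. Where it says the series, first, only, none or still open, it means among the compounds named here.

Three compounds share one core and differ only in the group on the amide nitrogen. In a functional assay on HCT-116 cells (Homo sapiens) for antiproliferative activity, read by MTT assay, with a stated time of 48 h (on this read-out higher numbers stand for weaker inhibition and lower numbers for stronger inhibition), compound 1 `O=C(Nc1cccc(/C=C/C(=O)c2nc3ccccc3[nH]2)c1)c1ccccc1` gives 2440 nM, compound 2 `O=C(Nc1cccc(/C=C/C(=O)c2nc3ccccc3[nH]2)c1)c1ccc(Br)cc1` gives 2230 nM, and compound 3 `COc1cccc(C(=O)Nc2cccc(/C=C/C(=O)c3nc4ccccc4[nH]3)c2)c1` gives 3680 nM. Compound 3 holds the top number of the three, yet its gaps to the others stay within the scatter: a 1.5-fold higher number from compound 1 to compound 3 (0.18 log units; within the scatter) and a 1.7-fold higher number from compound 2 to compound 3 (0.22 log units; within the scatter). Compound 4 `O=C(/C=C/c1cccc(NS(=O)(=O)c2ccc(Cl)cc2)c1)c1nc2ccccc2[nH]1` differs from compound 3 in one place: (4-chlorophenyl)sulfonyl in place of (3-methoxyphenyl)carbonyl on a nitrogen on an aromatic ring. Among the compounds with values here, no measured step exchanges a carbonyl for a sulfonyl, so that part rests on nothing; the swap of one aromatic ring for another echoes the step from compound 2 to compound 3, and a 1.1-fold lower number from compound 1 to compound 2 (0.04 log units; within the scatter) shows a halogen changing little. A step no larger than the scatter is therefore expected, a 1.4-fold lower number from compound 3 to compound 4 (0.15 log units; within the scatter). Compound 4 is estimated at 2600 nM, between 900 nM and 7500 nM.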

Compound 4, half-maximal inhibitory concentration: 1960 nM
Estimate against measurement, compound 4: 1.3-fold (0.12 log units) above, and the stated range covers the measured number.
By their numbers in this assay, from the lowest: compounds 4, 2, 1 and 3 (each within the scatter of the next).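

In this assay, a sulfonyl group on this nitrogen gives a number in the same range as all three carbonyl groups, with (4-chlorophenyl)sulfonyl in place of (3-methoxyphenyl)carbonyl (a 1.9-fold lower number from compound 3 to compound 4 (0.27 log units; within the scatter)), (4-bromophenyl)carbonyl (a 1.1-fold lower number from compound 2 to compound 4 (0.06 log units; within the scatter)) and benzoyl (a 1.2-fold lower number from compound 1 to compound 4 (0.10 log units; within the scatter)). Each step also changes the aromatic ring, so the sulfonyl is not seen alone. No measurement at hand accounts for these results.

The compounds shown leave open whether a plain phenylsulfonyl group would behave alike. They also leave open what a free amine or a small acetyl group on this nitrogen would give.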